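The source may hold more compounds than are shown below. What is called first, only, known or untested is meant among the compounds shown, and "the series" means these compounds.

Compound 1 `COc1cc(C)c(-c2cccc(COc3ccc(S(=O)(=O)CC(=O)O)cc3)c2)c(C)c1` is the reference point. In a functional assay on CHO cells for agonist activity at Free fatty acid receptor 1 (Homo sapiens), read by FLIPR and calcium flux (a lower number here means that less compound is needed, a higher number that more compound is needed for the effect), compound 1 gives 57.5 nM, the lowest of the two plain numbers shown here. Compound 2 `Cc1cc(OCC2CC2)cc(C)c1-c1cccc(COc2ccc(S(=O)(=O)CC(=O)O)cc2)c1` gives 79.4 nM, and the step of a 1.4-fold higher number from compound 1 to compound 2 (0.14 log units; within the scatter) shows that a cyclopropyl in place of hydrogen on a saturated chain carbon bound to an oxygen on an aromatic ring changes little. Compound 3 `COc1cc(C)c(-c2cccc(COc3ccc(S(=O)(=O)C(C)C(=O)O)cc3)c2)c(C)c1` gives only a limit of the assay, > 1000 nM, so its true number is not known. The step of an at least 17-fold higher number from compound 1 to compound 3 (1.24 log units; beyond the scatter) shows that a methyl in place of hydrogen on a saturated chain carbon bound to a carbonyl carbon and a sulfonyl sulfur costs a great deal. Compound 4 `Cc1ccc(C)n1-c1cccc(COc2ccc(S(=O)(=O)CC(=O)O)cc2)c1` differs from compound 1 in another part of the molecule: 2,5-dimethyl-1H-pyrrol-1-yl in place of 4-methoxy-2,6-dimethylphenyl on an aromatic carbon. Neither measured step tests this kind of change; the step to compound 2 only alters a substituent of the group that leaves, and the step to compound 3 alters the acid chain. Exchanging a whole aromatic ring for a smaller one is a larger change than either, so for compound 4 a moderate loss is expected, a 4.3-fold higher number from compound 1 to compound 4 (0.64 log units; beyond the scatter). The estimate for compound 4 is 250 nM, with a likely range from 80 nM to 1000 nM.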

Compound 4, half-maximal effective concentration: 129 nM
Compound 4: middle estimate off by 1.9-fold (0.29 log units), on the high side; the measured number falls inside the stated range.
By their numbers in this assay, from the lowest: compounds 1, 2 and 4 (each within the scatter of the next, the first and the last beyond it). At a limit, above all of these: compound 3.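

The aromatic carbon meta to a large group accepts more than a change of substituent on the ring it carries: the whole 4-methoxy-2,6-dimethylphenyl can be exchanged for 2,5-dimethyl-1H-pyrrol-1-yl at a modest cost (a 2.2-fold higher number from compound 1 to compound 4 (0.35 log units; beyond the scatter)). So a six-membered aromatic ring of carbon only is not needed at this place for a plain number in this assay, since a smaller five-membered aromatic ring with a hetero atom also gives one. Nothing measured here tells which feature of the two rings sets the size of this step.

From the compounds shown here alone, whether the methyl groups on the pyrrole ring matter remains open. So does the outcome with a pyridine ring, or with a saturated ring such as piperidine, on this carbon.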